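A few compounds are considered here, and "the series" means these few. Any claim that something is new, unique, unknown or untested is made for them only; others in the source may bear on it.

Measured compounds:
compound 1, `O=C(O)c1ccccc1-c1ccc(CCc2ncc(CCC3CCCCC3)[nH]2)cc1`, 642 nM in an in vitro functional assay on cells for agonist activity at Bombesin receptor subtype-3 (Homo sapiens), read by luminescence and calcium flux; a higher number here means that more compound is needed for the effect, a lower number that less compound is needed
compound 2, `Cc1cccc(Cc2cnc(CCc3ccc(-c4ccccc4C(=O)O)cc3)[nH]2)c1`, 4310 nM in this assay
compound 3, `COc1ccccc1Cc1cnc(CCc2ccc(-c3ccccc3C(=O)O)cc2)[nH]1`, 1720 nM in this assay

Of the three, compound 1 stands at the lowest number, and its steps to the other two both lie beyond the scatter: a 6.7-fold higher number from compound 1 to compound 2 (0.83 log units; beyond the scatter) and a 2.7-fold higher number from compound 1 to compound 3 (0.43 log units; beyond the scatter). Between the two aromatic variants the gap is a 2.5-fold lower number from compound 2 to compound 3 (0.40 log units; beyond the scatter).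

Compound 4, `O=C(O)c1ccccc1-c1ccc(CCc2ncc(CCc3ccccc3)[nH]2)cc1`, is not yet measured in this assay. It differs from compound 1 in one place: phenyl in place of cyclohexyl on a saturated chain carbon, two bonds along the chain from an aromatic carbon. The two steps that bear on it are those from compound 1 to compound 2 and from compound 1 to compound 3, since in both a saturated carbon ring on the chain gives way to an aromatic one, though cut one bond further out. Both were modest rises, a 6.7-fold higher number from compound 1 to compound 2 (0.83 log units; beyond the scatter) and a 2.7-fold higher number from compound 1 to compound 3 (0.43 log units; beyond the scatter). Nothing here shows a substituted and an unsubstituted phenyl side by side, so the size is uncertain, but a modest rise in the number is expected for compound 4, about a 2.8-fold higher number from compound 1 to compound 4 (0.45 log units; beyond the scatter). Compound 4 is therefore estimated at 1800 nM, with a range from 700 nM to 5000 nM.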

Compound 4, half-maximal effective concentration: 1320 nM
For compound 4 the middle estimate is 1.4-fold (0.13 log units) above the measured one; measured number inside the range.
By their numbers in this assay, from the lowest: compound 1; then compounds 4 and 3 (each within the scatter of the next); then compound 2.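

Compound 4 gives the ring change on its own, with the chain of compound 1 left as it is, whereas compounds 2 and 3 also carry a substituted ring on a shorter chain. In this assay the change from cyclohexyl to phenyl costs only a modest step (a 2.1-fold higher number from compound 1 to compound 4 (0.31 log units; beyond the scatter)) and compound 1 keeps the lowest number of the four, so a saturated ring is favoured here but an aromatic ring at this place is still tolerated. Among the aromatic compounds, compound 4 cannot be told apart from the 2-methoxyphenyl compound (a 1.3-fold lower number from compound 3 to compound 4 (0.11 log units; within the scatter)), while the 3-methylphenyl compound stands clearly apart (a 3.3-fold lower number from compound 2 to compound 4 (0.51 log units; beyond the scatter)), and nothing given here accounts for these differences.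

Still open, from the compounds shown here alone, is whether a longer chain would lower the number further, and whether a piperidine ring at this place would behave like cyclohexyl or like phenyl. Also open, going by these compounds, is how a methyl or methoxy group on the phenyl of compound 4 would shift the number on this same chain.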